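The compounds below may be only part of what the source reports. "The series", "measured", "known", "first", "only" and "open" are said of these compounds alone.

In a functional assay on U-373MG ATCC cells (Homo sapiens), read by thymidine incorporation (on this read-out higher numbers stand for weaker inhibition and lower numbers for stronger inhibition), three glycolipid analogues have been measured. Compound 1 `C=CCCC(=O)N[C@H]1[C@@H](OCCCCCCCCCCCCCCCC)O[C@H](CO)[C@@H](O)[C@@H]1O` gives a limit of > 50 uM, so no number is known for it. Compound 2 `CCCCCCCC/C=C\CCCCCCCC(=O)N[C@H]1[C@@H](OCCCCCCCC)O[C@H](CO)[C@@H](O)[C@@H]1O` gives 13.3 uM. Compound 3 `CCCCC(=O)N[C@H]1[C@@H](OCCc2ccccc2)O[C@H](COCC(CO)(CO)COS(=O)(=O)O)[C@@H](O)[C@@H]1O` gives 6.7 uM, the lower of the two numbers that are known, though its gap to compound 2 stays within the usual scatter of this assay, so the two cannot be ordered. The result of compound 1 is a limit of > 50 uM in this assay, at which 1 of the 3 values shown sits, and cannot be placed against either of the other two.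

Compound 4 `CCCCC(=O)N[C@H]1[C@@H](OCCc2ccccc2)O[C@H](COCC(O)CO)[C@@H](O)[C@@H]1O` has not yet been measured. It differs from compound 3 in one place: 1,2-dihydroxyethyl in place of 2-hydroxy-1-(hydroxymethyl)-1-((sulfooxy)methyl)ethyl on a saturated chain carbon bound to an oxygen on a saturated carbon. Within the data shown here, no measured pair in this set shows what such a change does, so the step from compound 3 to compound 4 in this assay can only be guessed at. The expectation is that the number for compound 4 stays close to that of compound 3, with a 1.3-fold higher number from compound 3 to compound 4 (0.13 log units; within the scatter) being a step of modest size in either direction. Compound 4 is therefore estimated at 9 uM, with a range from 2.5 uM to 35 uM, the measurement being awaited.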

Compound 4, concentration for 50% inhibition: > 50 uM
Compound 4: only a limit was reported; the forecaster's own chance of this, stated with the estimate: 15%; at least 5.5-fold (0.74 log units) between middle value and limit.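

Until now no single change could be read in this set, so this pair gives the first view of what the group at this position does in this assay. Replacing 2-hydroxy-1-(hydroxymethyl)-1-((sulfooxy)methyl)ethyl with 1,2-dihydroxyethyl, on a saturated chain carbon bound to an oxygen on a saturated carbon, gives an at least 7.4-fold higher number from compound 3 to compound 4 (0.87 log units; beyond the scatter), so this position is not indifferent to the change, and the inhibition seen for compound 3 depends on something in the group that leaves. The result for compound 4 is a limit and not a number, and it joins that of compound 1 at the same ceiling: the limit of > 50 uM in this assay, at which 2 of the 4 values shown sit.

The step removes several features together, so the compounds shown cannot say whether the sulfooxy part alone accounts for it or whether the added hydroxymethyl arms also contribute, and how far compound 4 lies beyond its limit also stays unknown. Equally open, from the compounds shown here alone, is how a carboxylic acid, an amine, or the same branched group without its sulfooxy part would read at this position in this assay.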